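Removing the Chloro Group from the Phenyl Ring

This account rests on a few compounds, and the source may have more. Where it says the series, first, only, none or still open, it means among the compounds named here.

The measured compounds and their values:
compound 1, `CCC(C(=O)N1CCN(c2ccccc2Cl)CC1)N1C(=O)CCC1=O`, 50%
compound 2, `CCC(C(=O)N1CCN(c2ccc(F)cc2)CC1)N1C(=O)CCC1=O`, 0%
compound 3, `CCC(C(=O)N1CCN(c2cccc(Cl)c2)CC1)N1C(=O)CCC1=O`, 75%

All three were tested in a functional assay on the whole organism (strain Swiss) with Mus musculus as the target, in the maximal electroshock model, with a stated time of 0.25 h, at a dose of 300 mg/kg by the intraperitoneal route; a higher number here means a stronger effect of the compound at the dose given, a lower number a weaker effect. Compound 3 stands highest of the three measured compounds; its nearest neighbour is compound 1, and compound 2 lies furthest from it. The steps between them are all beyond the scatter: a number 25 percentage points higher from compound 1 to compound 3 (beyond the scatter), a number 50 percentage points lower from compound 1 to compound 2 (beyond the scatter), and a number 75 percentage points higher from compound 2 to compound 3 (beyond the scatter).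

Compound 4, `CCC(C(=O)N1CCN(c2ccccc2)CC1)N1C(=O)CCC1=O`, has not yet been measured. It differs from compound 3 in one place: hydrogen in place of chloro on an aromatic carbon. The change sits meta to a large group, and read one bond further out it is 3-chlorophenyl to phenyl.

Going by the values given here, none of the measured steps removes a halogen outright; they only move it or exchange it. Those steps show that where the halogen sits on the phenyl ring moves the read-out strongly, with the 3-chlorophenyl compound 3 on top. Among the compounds with values here, compound 4 carries no halogen at all, so the account has no direct precedent. With the halogen gone, the result for compound 4 is expected to fall, giving a number 50 percentage points lower from compound 3 to compound 4 (beyond the scatter). Compound 4 is therefore estimated at 25%, within the range 0% to 75%.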

Compound 4, a percentage reported as activity, at one dose (the size of the read-out at that dose, not a potency): 75%
For compound 4 the middle estimate is 50 percentage points below the measured one; measured number inside the range.
By their numbers in this assay, from the lowest: compound 2; then compound 1; then compounds 3 and 4 (each within the scatter of the next).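

In this assay, taking the chloro group away from the aromatic carbon meta to a large group gives no change at the digits printed from compound 3 to compound 4 (within the scatter), so at this place the chlorine is not needed for the effect seen at this dose. The same unsubstituted phenyl compound also shows a number 25 percentage points higher from compound 1 to compound 4 (beyond the scatter) and a number 75 percentage points higher from compound 2 to compound 4 (beyond the scatter), which places the chloro group of compound 1 and the fluoro group of compound 2 below the plain ring in this read-out, while the chloro group of compound 3 cannot be told apart from hydrogen. The data offered here contain nothing that accounts for these differences between the halogen-bearing compounds.

As far as these compounds go, whether a methyl, a methoxy group or a nitrile at the place of the chloro group would stay level with hydrogen, or fall as the groups in compound 1 and compound 2 do, remains open. The read-out also comes from a single dose and a single time, so the level standing of compound 3 and compound 4 says nothing about whether their potencies match or whether they would stay level at lower doses.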